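The compounds below may be only part of what the source reports. "The series", "measured", "known", "first", "only" and "open" are said of these compounds alone.

In a functional assay, read by spectrophotometry, with a stated time of 30 min, tested at 50 uM (a lower number here means a weaker effect, a higher number a stronger effect of the compound at the concentration tested), the three measured compounds give these numbers:

Compound 1 `COc1cc(/C=C/c2nc3cccnc3n(CC(=O)O)c2=O)ccc1O`: 75.6%
Compound 2 `COc1cc(/C=C/c2nc3cc(Cl)cnc3n(CC(=O)O)c2=O)ccc1O`: 81.8%
Compound 3 `O=C(O)Cn1c(=O)c(/C=C/c2ccc(O)c(O)c2)nc2cc(Br)cnc21`: 82.4%

Compound 3 stands highest of the three numbers, but its gap to compound 2 and its gap to compound 1 both lie within the usual scatter, so the three cannot be told apart with confidence. Compound 4 `COc1cc(/C=C/c2nc3cc(Br)cnc3n(CC(=O)O)c2=O)ccc1O` differs from compound 3 in one place: methyl in place of hydrogen on an oxygen on an aromatic ring. For the measured compounds named here, the only measured step, a number 6.2 percentage points higher from compound 1 to compound 2 (within the scatter), concerns a different change and was itself within the scatter; no measured step shows what swapping the hydrogen on this oxygen for methyl does here. What can be said is that the same 4-hydroxy-3-methoxyphenyl group as in compound 4 is carried by compound 2, which gives 81.8%. Going by the values given here, that number is close to the one for compound 3. The step to compound 4 is therefore expected to be a number 1.4 percentage points lower from compound 3 to compound 4 (within the scatter), not beyond the scatter. Compound 4 is estimated at 81%, between 71% and 91%.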

Compound 4, a percentage reported as activity, at one concentration (the size of the read-out at that concentration, not a potency): 75.4%
The estimate for compound 4 lay 5.6 percentage points above the measured number, within the range that was stated.
By their numbers in this assay, from the lowest: compounds 4, 1, 2 and 3 (each within the scatter of the next).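

In this assay the change on the oxygen on an aromatic ring can now be read directly: hydroxy to methoxy gives a number 7 percentage points lower from compound 3 to compound 4 (within the scatter) so methyl in place of hydrogen there shifts the number by no more than repeated measurements would. The aromatic carbon carrying the halogen can also be read further, as bromo in place of chloro gives a number 6.4 percentage points lower from compound 2 to compound 4 (within the scatter) and bromo in place of hydrogen gives a number 0.2 percentage points lower from compound 1 to compound 4 (within the scatter) so neither halogen stands apart from hydrogen at that carbon. All four compounds therefore remain within the scatter of one another.

As far as these compounds go, whether a longer chain such as ethyl on this oxygen, or an amine in place of the hydroxy, would separate from these numbers stays open. Nothing measured here offers an explanation for the numbers.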